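Swapping trifluoromethyl for hydroxy on a tetrahydroisoquinoline amide

The source may report more compounds than this note shows. Statements on the series, on what has been measured and on what is new or still open speak of the compounds shown alone.

Measured so far:
compound 1, `O=C(Nc1ccccc1O)C1c2ccccc2CCN1C(=O)c1ccc(Cl)cc1`, > 10000 nM
compound 2, `O=C(Nc1ccccc1C(F)(F)F)C1NCCc2ccccc21`, > 10000 nM

In a functional assay on NUGC-3 cells (Homo sapiens) for inhibition, read by sulforhodamine B assay, with a stated time of 48 h (a lower number here means a stronger inhibitor of growth, a higher number a weaker inhibitor of growth), compound 2 gives only a limit, not a number. The same holds for compound 1: its value of > 10000 nM is a limit as well, so both measured compounds sit at the limit of > 10000 nM in this assay, at which 2 of the 2 values shown sit. Among the measured compounds shown here, there is no measured step that connects them, and nothing yet shows how far apart they might really be.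

Compound 3, `O=C(Nc1ccccc1O)C1NCCc2ccccc21`, is not measured yet. It arises from compound 2 by one change, (hydroxy in place of trifluoromethyl on an aromatic carbon), that is, hydroxy in place of trifluoromethyl on an aromatic carbon. For the measured compounds named here, with no measured step to lean on, the expectation is that the step from compound 2 to compound 3 stays within the usual scatter, with compound 3 most likely reported again as a limit, an expected step that the limit leaves unreadable from compound 2 to compound 3. Compound 3 is therefore estimated at 12000 nM, within a range of 3000 nM to 40000 nM.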

Compound 3, concentration for 50% growth inhibition: > 10000 nM
Compound 3: only a limit was reported (the forecaster's own chance of this, stated with the estimate: 75%); the middle value is on the limit's open side.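

Compound 3 also gives only a limit, so the steps to it from compound 2 and from compound 1 cannot be read: the limit of > 10000 nM in this assay, at which 3 of the 3 values shown sit.

The compounds shown leave open how much hydroxy, trifluoromethyl or the (4-chlorophenyl)carbonyl group changes growth inhibition.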